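The source may report more compounds than this note shows. Statements on the series, on what has been measured and on what is new or still open speak of the compounds shown alone.

Three compounds on the shared core have numbers in a functional assay on MIA PaCa-2 cells (Homo sapiens) for inhibition, read by MTT assay, with a stated time of 48 h, tested at 10 uM; on this read-out higher numbers stand for more inhibition of growth at the one concentration tested and lower numbers for less inhibition of growth. Compound 1 (`Cc1cc(=O)c2c(O)c(CN3CCCC3)c(O)c([C@H]3CCN(C)C[C@H]3O)c2o1`) gives 28%, compound 2 (`CCOC(=O)N1CCN(Cc2c(O)c([C@H]3CCN(C)C[C@H]3O)c3oc(C)cc(=O)c3c2O)CC1`) gives 4%, and compound 3 (`Cc1oc2c([C@H]3CCN(C)C[C@H]3O)c(O)cc(O)c2c(=O)c1C(O)c1c(Cl)cccc1Cl`) gives 0%. Compound 3 thus stands within the scatter of compound 2 and clearly under compound 1.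

Compound 4 (`CCOc1ccc(Br)c(C(O)c2c(C)oc3c([C@H]4CCN(C)C[C@H]4O)c(O)cc(O)c3c2=O)c1`) is not yet measured and differs from compound 3 as follows: 2-bromo-5-ethoxyphenyl in place of 2,6-dichlorophenyl on a saturated chain carbon bound to an aromatic carbon and an oxygen on a saturated carbon. Among the compounds with values here, the only measured step is a number 24 percentage points lower from compound 1 to compound 2 (beyond the scatter). It exchanges pyrrolidin-1-yl, not the group changed here, so it bears only indirectly, as a sign of the size a single exchange can reach in this assay. Within the data shown here, no measured step tests any replacement of 2,6-dichlorophenyl, so the data give no firm direction. A small rise remains possible, since compound 3 stands at 0%. The expected change is a number 6 percentage points higher from compound 3 to compound 4 (within the scatter), estimated to stay within the scatter. For compound 4 the estimated value is 6%, with an expected range of 0% to 22%.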

Compound 4, percent growth inhibition at one concentration: 4%
Estimate against measurement, compound 4: 2 percentage points above; the range from low to high includes it.
By their numbers in this assay, from the lowest: compounds 3, 2 and 4 (each within the scatter of the next); then compound 1.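

Exchanging 2,6-dichlorophenyl for 2-bromo-5-ethoxyphenyl on a saturated chain carbon bound to an aromatic carbon and an oxygen on a saturated carbon gives a number 4 percentage points higher from compound 3 to compound 4 (within the scatter) in this assay. Within the data shown here, this is the first measured exchange at this place, and the two aryl groups, which differ in halogen and in the ethoxy group, read alike, so this one exchange opens no measurable difference at the one concentration tested. Nothing at hand explains this outcome.

On these data alone, whether a phenyl ring carrying a carboxylic acid or a dimethylamino group would read differently at this place stays open. So does whether a group without an aromatic ring, such as a cyclohexyl or a longer alkyl chain, would move the number on this core.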